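A few compounds are considered here, and "the series" means these few. Any claim that something is new, unique, unknown or untested is made for them only; others in the source may bear on it.

Of the compounds shown here, three sharing a core have been tested in a functional assay on LOX IMVI cells (Homo sapiens) for cytotoxicity, read by MTT assay, with a stated time of 24 h; on this read-out lower numbers stand for stronger inhibition and higher numbers for weaker inhibition. There, compound 1 (`COc1cc(-c2nc(-c3ccccc3)[nH]c2-c2ccnc(NCCCNS(=O)(=O)c3cccc4ccccc34)n2)ccc1F`) gives 14900 nM, compound 2 (`COc1cc(-c2nc(-c3ccccc3)[nH]c2-c2ccnc(NCCCNS(=O)(=O)c3cccc4ccccc34)n2)ccc1Cl`) gives 13500 nM and compound 3 (`Cc1ccc(S(=O)(=O)NCCCNc2nccc(-c3[nH]c(-c4ccccc4)nc3-c3ccc(F)c(O)c3)n2)cc1`) gives 26300 nM. The gaps from compound 3 to the other two both lie within the usual scatter, so these numbers do not set it apart from them.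

Compound 4 (`O=S(=O)(NCCCNc1nccc(-c2[nH]c(-c3ccccc3)nc2-c2ccc(F)c(O)c2)n1)c1cccc2ccccc12`) differs from compound 3 in one place: naphthalen-1-yl in place of 4-methylphenyl on a sulfonyl sulfur. In words, naphthalen-1-yl takes the place of 4-methylphenyl on a sulfonyl sulfur.

Among the measured compounds shown here, the only measured step, a 1.1-fold lower number from compound 1 to compound 2 (0.04 log units; within the scatter), is chloro in place of fluoro on an aromatic carbon. For the measured compounds named here, it is small, but it does not touch the sulfonyl group, so no measured step tests this change directly. The closest evidence is indirect. Compound 1 and compound 2 already carry naphthalen-1-yl, yet they also differ from compound 3 elsewhere, and compound 1 at 14900 nM still lies within the scatter of compound 3 at 26300 nM.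

A change no larger than the scatter is therefore expected, and the estimated step is a 1.5-fold lower number from compound 3 to compound 4 (0.16 log units; within the scatter). For compound 4 the estimated value is 18000 nM, with an expected range from 9000 nM to 36000 nM.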

Compound 4, half-maximal inhibitory concentration: 3710 nM
Compound 4: the middle estimate sits 4.9-fold (0.69 log units) above what was measured; measured number outside the range, below it.
By their numbers in this assay, from the lowest: compound 4; then compounds 2, 1 and 3 (each within the scatter of the next).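

Among the compounds shown here, the aromatic group on the sulfonyl sulfur does matter in this assay: naphthalen-1-yl in place of 4-methylphenyl gives a 7.1-fold lower number from compound 3 to compound 4 (0.85 log units; beyond the scatter), the first step in this set to lie beyond the scatter. For the compounds shown here, with naphthalen-1-yl held fixed, the group on the other aromatic ring matters too: hydrogen in place of methyl on the oxygen gives a 4.0-fold lower number from compound 1 to compound 4 (0.60 log units; beyond the scatter), and 4-fluoro-3-hydroxyphenyl in place of 4-chloro-3-methoxyphenyl gives a 3.6-fold lower number from compound 2 to compound 4 (0.56 log units; beyond the scatter), so the sulfonyl position is not the only place where the number moves. Nothing available here explains why either change goes with a lower number.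

These compounds leave open whether the gain belongs to naphthalen-1-yl in particular or would also appear with another ring system on the sulfur, such as naphthalen-2-yl or a quinoline. They also leave open how a longer chain on the sulfonamide nitrogen, or an amine on the naphthalene ring, would change the number.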